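This account rests on a few compounds, and the source may have more. Where it says the series, first, only, none or still open, it means among the compounds named here.

Working notes on the series.

Compound 1 `CO[C@@H]1C=C(COC(C)=O)C(=O)[C@@H]2O[C@@](C)(OC)[C@](C)(OC)O[C@@H]12` and compound 2 `CO[C@H]1C=C(COC(C)=O)C(=O)[C@@H]2O[C@@](C)(OC)[C@](C)(OC)O[C@@H]12` share one core and carry a methoxy group on the ring; in an assay on isolated protein for inhibition of glutathione S-transferase Mu 1 (Homo sapiens), read by spectrophotometry, with a stated time of 3 min (on this read-out lower numbers stand for stronger inhibition and higher numbers for weaker inhibition), compound 1 gives "not determined" (no result reported) and compound 2 gives "not determined" (no result reported), so compound 2 stands without a number on this read-out. The two are related by the fact that compounds 1 and 2 differ only in the configuration as drawn, and nothing more can be said of them against each other. Compound 3 `CCCCCCCCCCO[C@H]1C=C(COC(C)=O)C(=O)[C@H](O)[C@H]1O` is built on a different core, a diol rather than the bisacetal, and carries the decyloxy group; in this assay compound 3 gives 13400 nM.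

Compound 4 `CCCCCCCCCCO[C@H]1C=C(COC(C)=O)C(=O)[C@@H]2O[C@@](C)(OC)[C@](C)(OC)O[C@@H]12` keeps the core of compound 2 and differs from it by nonyl in place of hydrogen on a saturated chain carbon bound to an oxygen on a saturated carbon. Within the data shown here, no measured step runs from compound 2 to compound 4, and compound 2 itself has no number, so the size of the change cannot be read from a pair in hand. On this assay the expectation is a value of the same order as that of compound 3, which carries the same decyloxy group and gives 13400 nM, with no direction claimed relative to compound 2.

Compound 4 is therefore estimated at 15000 nM, within a range of 4000 nM to 60000 nM.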

Compound 4, half-maximal inhibitory concentration: 33600 nM
Compound 4: the middle estimate sits 2.2-fold (0.35 log units) below what was measured; low and high end bracket the measured number.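

In this assay, among these compounds, compound 2 gives "not determined" (no result reported), so no step from it to compound 4, at 33600 nM, can be read. The compounds shown leave open how far methoxy to decyloxy on the shared core shifts inhibition, and whether the configuration as drawn, which alone separates compound 1 from compound 2, has any bearing on it.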